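The compounds below may be only part of what the source reports. "The series", "measured", "known", "first", "only" and "open" are said of these compounds alone.

Measured in a functional assay on HT-29 cells (Homo sapiens) for inhibition, read by MTT assay, with a stated time of 48 h; a lower number here means a stronger inhibitor, a higher number a weaker inhibitor:
- compound 1 `COc1ccc(CSc2nnc(-c3cc(OC)c(OC)c(OC)c3)n2-c2ccc(OC)cc2)cc1`: > 60000 nM
- compound 2 `COc1ccc(-n2c(SCC(=O)c3ccccc3)nnc2-c2cc(OC)c(OC)c(OC)c2)cc1`: > 60000 nM
- compound 3 `COc1ccc(-n2c(SCC(=O)c3ccc(F)cc3)nnc2-c2cc(OC)c(OC)c(OC)c2)cc1`: 42500 nM

The value of compound 1 is a limit of the assay. The value of compound 2 is likewise a limit. Among the measured compounds shown here, compound 3, at 42500 nM, therefore holds the only actual number in the set.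

Compound 4 `COc1ccc(NC(=O)CSc2nnc(-c3cc(OC)c(OC)c(OC)c3)n2-c2ccc(OC)cc2)cc1` differs from compound 3 by (4-methoxyphenyl)amino in place of 4-fluorophenyl on a carbonyl carbon, which is (4-methoxyphenyl)amino in place of 4-fluorophenyl on a carbonyl carbon. The relevant measured steps are an at least 1.4-fold lower number from compound 1 to compound 3 (0.14 log units; that floor lies within the scatter) and an at least 1.4-fold lower number from compound 2 to compound 3 (0.14 log units; that floor lies within the scatter), and both floors lie within the scatter. The remaining step, a step that the two limits leave unreadable from compound 1 to compound 2, cannot be read. None of these steps covers this replacement, so no step beyond the scatter is expected in this assay. The expected step is a 1.2-fold lower number from compound 3 to compound 4 (0.08 log units; within the scatter). For compound 4 the estimated value is 35000 nM, with an expected range of 8000 nM to 60000 nM.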

Compound 4, half-maximal inhibitory concentration: 45300 nM
Compound 4: middle estimate off by 1.3-fold (0.11 log units), on the low side; low and high end bracket the measured number.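

In this assay, the carbonyl carbon carries (4-methoxyphenyl)amino in place of 4-fluorophenyl with no step beyond the scatter, at a 1.1-fold higher number from compound 3 to compound 4 (0.03 log units; within the scatter). Compound 4 thus gives a second actual number in the set, and the only one with a (4-methoxyphenyl)carbamoyl group. The floors against the two limit compounds add little, at an at least 1.3-fold lower number from compound 2 to compound 4 (0.12 log units; that floor lies within the scatter) and an at least 1.3-fold lower number from compound 1 to compound 4 (0.12 log units; that floor lies within the scatter).

Open, from the compounds shown here alone, is whether a carboxylic acid or a morpholine amide on this carbonyl carbon would give a step beyond the scatter. Steps from compound 1 and compound 2 remain floors: the limit of > 60000 nM in this assay, at which 2 of the 4 values shown sit.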